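A few compounds are considered here, and "the series" means these few. Any claim that something is new, unique, unknown or untested is made for them only; others in the source may bear on it.

Measured compounds in a functional assay on A549 cells (Homo sapiens) for cytotoxicity, read by MTT assay, with a stated time of 24 h; on this read-out higher numbers stand for weaker inhibition and lower numbers for stronger inhibition:

- compound 1, `C=CC1=C(C(=O)Nc2ccccc2)C(c2ccc(OC)cc2)OC1`: > 100000 nM (a limit of the assay, not a number)
- compound 2, `C=CC1=C(C(=O)NC(C)(C)C)C(c2ccc(F)cc2)OC1`: > 100000 nM (likewise a limit)

Compound 2 stands at the upper limit of this assay, and compound 1 does the same; both values shown are limits, as noted in the limit of > 100000 nM in this assay, at which 2 of the 2 values shown sit. Among the compounds with values here, no step between measured compounds can be drawn, since the two differ at more than one place and neither has a number.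

The compound still to be measured is compound 3, `C=CC1=C(C(=O)Nc2ccccc2)C(c2ccc(F)cc2)OC1`. It differs from compound 2 by phenyl in place of tert-butyl on an amide-type nitrogen. The change is the same amide substituent that compound 1 already carries, and compound 1 sits at the limit in this assay.

With no measured step to lean on, and with both amide variants shown so far at the limit, no step beyond the scatter is expected in either direction for compound 3. The expected step that the limit leaves unreadable from compound 2 to compound 3 is essentially none, and the most likely outcome is that compound 3 is again reported only as a limit. The estimate for compound 3 in this assay is 150000 nM, with a range from 50000 nM to 500000 nM.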

Compound 3, half-maximal inhibitory concentration: > 100000 nM
Compound 3 ended at the assay's limit; the forecaster's own chance of this, stated with the estimate: 85%; the middle value lies beyond the limit too.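

In this assay compound 3 gives > 100000 nM, a limit and not a number. No step from compound 1 or compound 2 to compound 3 can be read, as all three compounds sit at the same limit: the limit of > 100000 nM in this assay, at which 3 of the 3 values shown sit.

The compounds shown leave open whether phenyl in place of tert-butyl, or fluoro in place of methoxy, changes the read-out at all in this assay.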